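This account rests on a few compounds, and the source may have more. Where it says the series, first, only, none or still open, it means among the compounds named here.

Measured compounds:
compound 1, `COc1cc(C(F)(F)F)cc(C(F)(F)F)c1C(=O)NC1(c2ccccc2)CCCN(S(C)(=O)=O)C1`, > 10000 nM
compound 2, `COc1ccc(C2(NC(=O)c3c(OC)cc(C(F)(F)F)cc3SC)CCCN(C)C2)cc1`, 170 nM

In an assay on cells for inhibition of sodium- and chloride-dependent glycine transporter 1 (Homo sapiens) (on this read-out lower numbers stand for an effect already at smaller amounts and higher numbers for an effect only at larger amounts of compound), compound 1 reaches only a limit of the assay, > 10000 nM. Going by the values given here, compound 2 is the one compound with a number in this assay, 170 nM. Compound 3, `COc1cc(C(F)(F)F)cc(SC)c1C(=O)NC1(c2ccncn2)CCCN(C)C1`, has not been measured; it differs from compound 2 in one place: pyrimidin-4-yl in place of 4-methoxyphenyl on a saturated ring carbon. Among the compounds with values here, no step between two measured compounds is available to guide this change. Compound 3 is expected to be somewhat weaker, with a step from compound 2 of a 2.9-fold higher number from compound 2 to compound 3 (0.47 log units; beyond the scatter), a change of modest size beyond the scatter. The estimated value of compound 3 is 500 nM, between 150 nM and 2500 nM.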

Compound 3, half-maximal effective concentration: 1700 nM
For compound 3 the middle estimate is 3.4-fold (0.53 log units) below the measured one; the measured number falls inside the stated range.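

Exchanging 4-methoxyphenyl for pyrimidin-4-yl on the saturated ring carbon gives a 10-fold higher number from compound 2 to compound 3 (1.00 log units; beyond the scatter) in this assay. This position therefore responds to the aromatic group it carries, and the response to this exchange lies beyond the scatter. Nothing given here accounts for the size of this step. From the compounds shown here alone, what a pyridin-4-yl or a 4-chlorophenyl group would give at this place remains open. The compounds shown therefore do not separate the departure of the methoxy group from the entry of the two ring nitrogens.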